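Swapping tert-butyl for 4-nitrophenyl on the shared core

A few compounds are considered here, and "the series" means these few. Any claim that something is new, unique, unknown or untested is made for them only; others in the source may bear on it.

Of the compounds shown here, three of one family have been measured so far in a functional assay on aorta with Alpha-1D adrenergic receptor (Rattus norvegicus) as the target; a lower number here means that less compound is needed, a higher number that more compound is needed for the effect. Compound 1, with the structure `CSc1ccc(Cc2nn(C(C)(C)C)c(=O)c3ccccc23)cc1`, gives in this assay only a limit of > 100000 nM. Compound 2, with the structure `Cn1nc(Cc2ccc3ccccc3c2)c2ccccc2c1=O`, likewise gives only a limit of > 10000 nM. Compound 3, with the structure `CC(C)(C)n1nc(Cc2ccc(Cl)cc2)c2ccccc2c1=O`, again gives only a limit of > 100000 nM. The one step that joins two of these compounds, a step that the two limits leave unreadable from compound 1 to compound 3, cannot be read in size because both ends of it sit at limits. Compound 3 therefore stands at the limit of > 100000 nM in this assay, at which 2 of the 3 values shown sit, and no compound shown has a genuine number: one value sits at the limit of > 10000 nM in this assay, at which 1 of the 3 values shown sits, and the other two at the limit of > 100000 nM in this assay, at which 2 of the 3 values shown sit.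

Compound 4, with the structure `O=c1c2ccccc2c(Cc2ccc(Cl)cc2)nn1-c1ccc([N+](=O)[O-])cc1`, differs from compound 3 by 4-nitrophenyl in place of tert-butyl on an aromatic nitrogen. Among the measured compounds shown here, no measured step concerns this exchange on the aromatic nitrogen, and the only step that exists is unreadable, so there is no basis to expect a change beyond the scatter in this assay. Compound 4 is therefore estimated to remain at a limit, roughly 100000 nM, between 10000 nM and 300000 nM, which would mean an expected step of a number no higher from compound 3 to compound 4 (the limit leaves the size open).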

Compound 4, half-maximal effective concentration: 29000 nM
Beside the measured number, compound 4's estimate is 3.4-fold (0.54 log units) above it; low and high end bracket the measured number.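

On the aromatic nitrogen of the shared core, 4-nitrophenyl in place of tert-butyl brings an at least 3.4-fold lower number from compound 3 to compound 4 (0.53 log units; beyond the scatter) in this assay. In this family, compound 4 gives 29000 nM, the first genuine number. Among the compounds shown here, this position can therefore change the result, something the earlier compounds could not show while each of them ended at a limit. The size of the step is only a minimum because compound 3 sits at a limit and not at a number: the limit of > 100000 nM in this assay, at which 2 of the 4 values shown sit.

On these data alone, it remains open whether the change depends on the aromatic ring itself or on the nitro group it carries, and a plain phenyl or a 4-aminophenyl on the same nitrogen would separate the two. It is also open whether the exchange would act the same way with the methylsulfanyl group of compound 1 in place of the chloro, as compound 4 is the only compound shown with an aromatic ring on this nitrogen.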